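Removing the chloro group from compound 1

The source may hold more compounds than are shown below. What is called first, only, known or untested is meant among the compounds shown, and "the series" means these compounds.

Compound 1 `CCCc1nc2ccccc2c(=O)n1/N=C/c1ccc(Oc2ccc(Cl)cc2)cc1` is the most lipophilic of the three compounds measured in a physicochemical assay for lipophilicity, in phosphate buffer, measured as octanol-water partition; a higher number here means a more lipophilic compound, a lower number a more polar compound: compound 1 gives 5.78. Compound 2 `Cc1nc2ccccc2c(=O)n1/N=C/c1ccc(Oc2ccc(Cl)cc2)cc1` gives 4.6 in this assay. Compound 3 `CCCc1nc2ccccc2c(=O)n1/N=C1/C(=O)Nc2ccccc21` differs from compound 1 in two places at once, and in this assay compound 3 gives 3.23.

Compound 4 `CCCc1nc2ccccc2c(=O)n1/N=C/c1ccc(Oc2ccccc2)cc1` is the compound still to be measured. It differs from compound 1 by one change: hydrogen in place of chloro on an aromatic carbon. Among the compounds with values here, the only single-place step among the measured compounds is a number 1.18 log units lower from compound 1 to compound 2 (beyond the scatter), and it concerns a different group on the shared core, so it offers no direct guide to the loss of a chloro group. Compound 3 differs from compound 1 in two places at once, and its value can only be compared as a whole.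

Within the data shown here, no measured step therefore speaks to this change directly. Compound 4 is nevertheless expected to sit lower than compound 1 in this assay, with an expected step of a number 0.68 log units lower from compound 1 to compound 4 (beyond the scatter) that should exceed the scatter. The value of compound 4 is estimated at 5.1, between 4.7 and 5.5.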

Compound 4, partition coefficient: 5.2
The estimate for compound 4 lay 0.10 log units below the measured number; measured number inside the range.
By their numbers in this assay, from the lowest: compound 3; then compound 2; then compound 4; then compound 1.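

In this assay, within the data shown here, the step of a number 0.58 log units lower from compound 1 to compound 4 (beyond the scatter) is the first reading of this place on the molecule, since the earlier single-place step concerned the chain on the shared core and not the far end of the molecule. It shows that the change from 4-chlorophenoxy to phenoxy, in which a single chlorine gives way to hydrogen and no ring, hydrogen-bond donor or hydrogen-bond acceptor enters or leaves, moves the number by more than the usual scatter, though this step is smaller than a number 1.18 log units lower from compound 1 to compound 2 (beyond the scatter) on the chain. Nothing among the data shown offers a reason for the size of this step.

From the compounds shown here alone, whether the same change from chloro to hydrogen would give a step of similar size on the shorter chain of compound 2 remains open, as the phenoxy partner of that compound does not appear here. Also open, going by these compounds, is how a fluoro, a methoxy, an amine or a carboxylic acid on the same aromatic carbon would compare with chloro and hydrogen in this assay when the rest of compound 1 stays unchanged.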